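From Compound 1 to Compound 4: One Carbon Longer

This account rests on a few compounds, and the source may have more. Where it says the series, first, only, none or still open, it means among the compounds named here.

Compound 1 `CCCNC(=S)NS(=O)(=O)c1ccc(-n2nc(C(=O)O)cc2C)cc1` was examined in a functional assay on the whole organism (blood, strain albino) with Mus musculus as the target, with stated times of 6 days and 4 h, at a dose of 0.4 mmol/kg by the oral route; on this read-out higher numbers stand for more inhibition at the one dose given (going by the name of the read-out) and lower numbers for less inhibition. In this assay compound 1 gives < 1%, which is a limit of the assay and not a number. Compound 2 `CCCNC(=S)NS(=O)(=O)c1ccc(-n2nc(C)cc2C)cc1` likewise gives < 1% in this assay, again a limit. Compound 3 `Cc1cc(C)n(-c2ccc(S(=O)(=O)NC(=O)NCc3ccccc3)cc2)n1` gives < 1%, also a limit. Going by the values given here, the only measured step between neighbours, a step that the two limits leave unreadable from compound 1 to compound 2, cannot be sized, since the limit of < 1% in this assay, at which 3 of the 3 values shown sit, leaves every value at the same floor. Compound 4 `CCCCNC(=S)NS(=O)(=O)c1ccc(-n2nc(C(=O)O)cc2C)cc1` differs from compound 1 by methyl in place of hydrogen on a saturated chain carbon, three bonds along the chain from an amide-type nitrogen. Among the compounds with values here, no measured step bears on this change, and all three values sit at the limit. Compound 4 is therefore expected at 1%, within 0% to 8%. The step of a number no lower from compound 1 to compound 4 (the limit leaves the size open) is estimated to lie within the scatter.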

Compound 4, a percentage reported as inhibition, in the whole organism at one dose (the size of the read-out at that dose, not a potency): < 1%
Compound 4 ended at the assay's limit; the forecaster's own chance of this, stated with the estimate: 70%; the middle value sits exactly at the limit.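

No step can be read between compound 1 and compound 4, because both sit at the same floor: the limit of < 1% in this assay, at which 4 of the 4 values shown sit.

The compounds shown leave open whether propyl to butyl, or any other change among them, alters inhibition in this assay.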